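The source may hold more compounds than are shown below. What is called first, only, known or untested is meant among the compounds shown, and "the series" means these compounds.

Measured compounds in this series:

compound 1 `COC(=O)c1ccc(NCc2cncn2Cc2cccc(Cl)c2)cc1-c1ccccc1` gives > 10000 nM, a limit of the assay and not a number.
compound 2 `Cc1ccccc1-c1cccc(NCc2cncn2Cc2ccccc2)c1` gives > 1000 nM, likewise only a limit.
compound 3 `c1ccc(-c2ccc(Cn3cncc3CNc3ccc(-c4cncs4)c(-c4ccccc4)c3)cc2)cc1` gives > 1000 nM, again a limit.

All three values come from a toxicity assay on NIH3T3 cells (Mus musculus) for cytotoxicity, read by resazurin assay; a lower number here means that less compound is needed, a higher number that more compound is needed for the effect. Compound 1 stands nowhere on a scale here: its value is a limit, and the two other values are limits as well, so no order among the three can be drawn. Two of the values sit at the limit of > 1000 nM in this assay, at which 2 of the 3 values shown sit. One value, that of compound 1, sits at the limit of > 10000 nM in this assay, at which 1 of the 3 values shown sits. Among the compounds with values here, no step between measured compounds that differ in one place is available, so nothing about the size of any single change in this assay is known from the series itself.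

Compound 4 `COC(=O)c1ccc(NCc2cncn2Cc2ccccc2)cc1-c1ccccc1` has not been measured. It differs from compound 1 by hydrogen in place of chloro on an aromatic carbon. With compound 1 returning only a limit, and the two other compounds returning only limits, the expected step in this assay is none beyond the usual scatter, in neither direction; the most likely outcome is again a limit rather than a number. Compound 4 is expected at 20000 nM, within 8000 nM to 60000 nM, and the expected step that the limit leaves unreadable from compound 1 to compound 4 is essentially flat.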

Compound 4, half-maximal effective concentration: > 1000 nM
Compound 4: a limit, no number; the forecaster's own chance of this, stated with the estimate: 85%; the middle value is on the limit's open side.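

Within the data shown here, compound 1 and compound 4 both return only limits in this assay, so no step between them can be read, and the change from 3-chlorobenzyl to benzyl has no readable size. The compounds shown leave open what concentration any of them needs for a half-maximal effect in this assay, and whether the chloro group changes it.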